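Swapping a hydroxyphenyl for a pyrrole on a thiosemicarbazone

The source may hold more compounds than are shown below. What is called first, only, known or untested is meant among the compounds shown, and "the series" means these compounds.

Measured so far:
- compound 1, `CC1=CC[C@H](C(C)(C)NC(=S)NN)CC1`: > 100000 nM
- compound 2, `CC1=CC[C@H](C(C)(C)NC(=S)N/N=C/c2ccccc2O)CC1`: 10900 nM

Compound 1 carries the bare thiosemicarbazide end on the shared core, and in a functional assay on NCI/ADR-RES cells (Homo sapiens) for inhibition, read by sulforhodamine B assay, with a stated time of 48 h (on this read-out higher numbers stand for weaker inhibition of growth and lower numbers for stronger inhibition of growth), compound 1 reaches only the limit of > 100000 nM, which is a limit of the measurement rather than a number. Compound 2 extends that end with a 2-hydroxyphenyl group, and in this assay compound 2 gives 10900 nM. Among the results shown, compound 2 is the only one with a proper number; the other result, (the limit of > 100000 nM in this assay, at which 1 of the 2 values shown sits), gives no number to compare against.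

Compound 3, `CC1=CC[C@H](C(C)(C)NC(=S)N/N=C/c2ccc[nH]2)CC1`, keeps the whole of compound 2 apart from one change: 1H-pyrrol-2-yl in place of 2-hydroxyphenyl on a carbon with a double bond to nitrogen. Going by the values given here, no measured pair differs in just this way, so the size of this step cannot be read from the data. A moderate weakening is expected, with the step from compound 2 to compound 3 estimated as a 1.8-fold higher number from compound 2 to compound 3 (0.26 log units; within the scatter), though a result within the scatter is also possible. In this assay compound 3 is therefore expected at about 20000 nM, most likely between 5000 nM and 80000 nM.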

Compound 3, concentration for total growth inhibition: > 100000 nM
Compound 3: no number, only a limit; the forecaster's own chance of this, stated with the estimate: 25%; middle value at least 5.0-fold (0.69 log units) from the limit.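

Putting 1H-pyrrol-2-yl in place of 2-hydroxyphenyl, on a carbon with a double bond to nitrogen, gives an at least 9.1-fold higher number from compound 2 to compound 3 (0.96 log units; beyond the scatter) in this assay. Going by these compounds alone, until now, the only comparison was between the bare thiosemicarbazide end of compound 1 and the extended end of compound 2, which left open whether any aromatic ring at this place would give a measurable result; compound 3 shows that, at least for this five-membered ring, having an aromatic ring there is not enough. Compound 3 gives only a limit rather than a number, so the full size of the change from compound 2 remains unknown, and the step from compound 1 to compound 3 cannot be read, leaving compound 2 as the only compound here with a number: the limit of > 100000 nM in this assay, at which 2 of the 3 values shown sit.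

The compounds shown do not reveal whether the hydroxyl or the six-membered ring of compound 2 matters more, since the change replaces both at once. A plain phenyl group or a 2-methoxyphenyl group at this place would help separate the two.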